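Lengthening the chain once more on the quinoline-isoxazole series

The source may hold more compounds than are shown below. What is called first, only, known or untested is meant among the compounds shown, and "the series" means these compounds.

Compounds measured so far in a functional assay on A549 cells (Homo sapiens) for inhibition, read by MTT assay, with a stated time of 24 h; on this read-out higher numbers stand for weaker inhibition and lower numbers for stronger inhibition:
- compound 1 `CCCCCc1cc2ccccc2nc1-c1cc(-c2ccccc2)no1`: 92300 nM
- compound 2 `CCCc1cc2ccccc2nc1-c1cc(-c2ccc(C(F)(F)F)cc2)no1`: 43900 nM
- compound 3 `CCCCc1cc2ccccc2nc1-c1cc(-c2ccc(C(F)(F)F)cc2)no1`: 9400 nM

Among these three numbers compound 3 stands lowest, that is, it is the strongest inhibitor of the set; compound 2 is nearest to it and compound 1 furthest, and both gaps lie beyond the scatter.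

Compound 4 `CCCCCc1cc2ccccc2nc1-c1cc(-c2ccc(C(F)(F)F)cc2)no1` differs from compound 3 by one change: methyl in place of hydrogen on a saturated chain carbon, four bonds along the chain from an aromatic carbon. In plain terms, the butyl chain on the shared core becomes a pentyl chain, while the trifluoromethyl-bearing ring is kept.

Within the data shown here, one measured step bears on this. The same kind of change, one bond closer to the ring, gave a 4.7-fold lower number from compound 2 to compound 3 (0.67 log units; beyond the scatter), so a longer chain helped there. Compound 1 also carries a pentyl chain, but with a plain phenyl ring instead, and its value is the weakest shown, so it does not settle the question for compound 4. In this assay the step from compound 3 to compound 4 is therefore expected to be a smaller improvement than the last one, a 1.4-fold lower number from compound 3 to compound 4 (0.16 log units; within the scatter). Compound 4 is estimated at 6500 nM, with a likely range from 2000 nM to 25000 nM.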

Compound 4, half-maximal inhibitory concentration: 28300 nM
Compound 4: middle estimate off by 4.4-fold (0.64 log units), on the low side; the whole stated range lies below it.
By their numbers in this assay, from the lowest: compound 3; then compounds 4 and 2 (each within the scatter of the next); then compound 1.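

In this assay, the one-carbon extension that helped in a 4.7-fold lower number from compound 2 to compound 3 (0.67 log units; beyond the scatter) turns against the series in a 3.0-fold higher number from compound 3 to compound 4 (0.48 log units; beyond the scatter), so the response to chain length is not steady, and the butyl chain gives the lowest number of the trifluoromethyl-bearing compounds. The two-carbon change, seen as a 1.6-fold lower number from compound 2 to compound 4 (0.19 log units; within the scatter), means that the propyl and pentyl chains cannot be told apart here. With the pentyl chain kept, adding trifluoromethyl still matters, as a 3.3-fold lower number from compound 1 to compound 4 (0.51 log units; beyond the scatter) shows. Nothing available explains why the trend turns at this chain length. Still open, from the compounds shown here alone, is whether a hexyl chain would continue the upward move in the numbers, and whether a chain carrying an amine or a carboxylic acid would follow the same pattern.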